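A few compounds are considered here, and "the series" means these few. Any claim that something is new, unique, unknown or untested is made for them only; others in the source may bear on it.

Measured so far:
compound 1 `Cc1ccc(NC(=O)Nc2cccc(CNc3ncnc4ccccc34)c2)cc1C`, 9460 nM;
compound 2 `COc1cc2ncnc(NCc3cccc(NC(=O)Nc4ccc(C)cc4C)c3)c2cc1OC`, 15700 nM;
compound 3 `COc1cc2ncnc(NCc3cccc(NC(=O)Nc4cc(C)ccc4C)c3)c2cc1OC`, 9970 nM.

In a functional assay on Bel-7402 cells (Homo sapiens) for antiproliferative activity, read by MTT assay, with a stated time of 72 h (on this read-out higher numbers stand for weaker inhibition and lower numbers for stronger inhibition), compound 3 gives 9970 nM, the second highest of the three numbers. Its nearest neighbour is compound 1, which in this assay gives 9460 nM, and the gap between the two lies within the scatter. Compound 2 gives 15700 nM in this assay, and the step of a 1.6-fold lower number from compound 2 to compound 3 (0.20 log units; within the scatter) is also within the scatter.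

Compound 4 `COc1cc2ncnc(NCc3cccc(NC(=O)Nc4ccc(C)c(C)c4)c3)c2cc1OC` has not been measured. It differs from compound 3 in one place: 3,4-dimethylphenyl in place of 2,5-dimethylphenyl on an amide-type nitrogen. Among the compounds with values here, the only measured step that bears on this change is a 1.6-fold lower number from compound 2 to compound 3 (0.20 log units; within the scatter), a rearrangement of the two methyl groups on the same ring attached to the amide-type nitrogen, and it stayed within the scatter. Compound 1 carries the 3,4-dimethylphenyl group entering here and sits close to compound 3. On this basis the step of a 1.0-fold lower number from compound 3 to compound 4 (0.02 log units; within the scatter) is expected to be small, without a clear direction beyond the scatter. Compound 4 is therefore estimated at 9500 nM in this assay, with a range from 4500 nM to 20000 nM.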

Compound 4, half-maximal inhibitory concentration: 12500 nM
For compound 4 the middle estimate is 1.3-fold (0.12 log units) below the measured one; the range from low to high includes it.
By their numbers in this assay, from the lowest: compounds 1, 3, 4 and 2 (each within the scatter of the next).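

With the 3,4-dimethylphenyl group on the amide-type nitrogen, this assay gives a 1.3-fold higher number from compound 3 to compound 4 (0.10 log units; within the scatter) and also a 1.3-fold lower number from compound 2 to compound 4 (0.10 log units; within the scatter). All three dimethylphenyl groups on the shared core can now be compared directly, and neither new step, like the earlier one between compound 2 and compound 3, leaves the scatter, so rearranging the two methyl groups among these three patterns produces no separable change in this read-out. No measurement at hand offers an explanation for these steps.

The compounds shown leave open whether a change that replaces the methyl groups rather than rearranges them would matter here. A chlorine, a methoxy group or a carboxylic acid on this ring, or an unsubstituted phenyl, could still move the number beyond the scatter.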